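Aryl replacement at the pyrazole carbon of compound 1

A few compounds are considered here, and "the series" means these few. Any claim that something is new, unique, unknown or untested is made for them only; others in the source may bear on it.

Among the measured compounds shown here, compound 1 `Cc1nn(-c2nc(-c3ccc(Cl)c(Cl)c3)c(SC(C)C)s2)c(C(=O)O)c1-c1cncnc1` gives 22000 nM in a functional assay on BJAB cells (Homo sapiens) for antiproliferative activity, with a stated time of 4 days (a higher number here means that more compound is needed for the effect, a lower number that less compound is needed), the highest of the three numbers known here. Compound 2 `Cc1nn(-c2nc(-c3ccc(Cl)c(Cl)c3)c(SC(C)C)s2)c(C(=O)O)c1-c1cnccn1` gives 14000 nM and compound 3 `Cc1cccc(-c2c(C)nn(-c3nc(-c4ccc(Cl)c(Cl)c4)c(SC(C)C)s3)c2C(=O)O)c1` gives 17000 nM, and both steps, a 1.6-fold lower number from compound 1 to compound 2 (0.20 log units; within the scatter) and a 1.3-fold lower number from compound 1 to compound 3 (0.11 log units; within the scatter), stay within the scatter. Compound 4 `COc1cc(Cl)cc(-c2c(C)nn(-c3nc(-c4ccc(Cl)c(Cl)c4)c(SC(C)C)s3)c2C(=O)O)c1` carries the change (3-chloro-5-methoxyphenyl in place of pyrimidin-5-yl on an aromatic carbon). The step to compound 3, which also puts a six-membered carbon ring in this place, is the one that bears on it, and it was small. Compound 4 is therefore expected to sit close to compound 1, with a 1.5-fold lower number from compound 1 to compound 4 (0.17 log units; within the scatter) not beyond the scatter. The estimate for compound 4 is 15000 nM, with a range from 6000 nM to 40000 nM.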

Compound 4, half-maximal effective concentration: 760 nM
For compound 4 the middle estimate is 20-fold (1.30 log units) above the measured one; the whole stated range lies above it.
By their numbers in this assay, from the lowest: compound 4; then compounds 2, 3 and 1 (each within the scatter of the next).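

In this assay this position turns out to respond strongly to the aryl group it carries, with a 29-fold lower number from compound 1 to compound 4 (1.46 log units; beyond the scatter), while the earlier replacements stayed within the scatter of one another. The 3-chloro-5-methoxyphenyl group also stands clear of the other two groups, with a 22-fold lower number from compound 3 to compound 4 (1.35 log units; beyond the scatter) and an 18-fold lower number from compound 2 to compound 4 (1.27 log units; beyond the scatter), so a six-membered aromatic ring of carbon only is not enough by itself, as the 3-methylphenyl group of compound 3 shows. Nothing given here explains the step.

From the compounds shown here alone, whether the chlorine, the methoxy group or the two together carry the step stays open, as does how a 3-chlorophenyl, 3-methoxyphenyl or 3-aminophenyl group would behave at this place.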